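Replacing the 3-cyclohexylpropyl chain of compound 2

This account rests on a few compounds, and the source may have more. Where it says the series, first, only, none or still open, it means among the compounds named here.

In an ADME assay on HOS cells (Homo sapiens) for cytotoxicity, read by luminescence and ATP content, with a stated time of 48 h (on this read-out higher numbers stand for lower toxicity in this test and lower numbers for higher toxicity in this test), compound 1 (`O=C(NCc1ccc(F)cc1F)c1c(O)c2cc(CCCCCO)cnc2n(O)c1=O`) gives > 250000 nM as its reading, which is a limit of the assay and not a number. Among the compounds with values here, compound 2 (`Nc1c(C(=O)NCc2ccc(F)cc2F)c(=O)n(O)c2ncc(CCCC3CCCCC3)cc12`) gives 27400 nM in this assay as the only actual number so far. Of the two readings, that of compound 2 is the lower one, on the side of higher toxicity in this test.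

Compound 3 (`CN(C)C(=O)/C=C/c1cnc2c(c1)c(N)c(C(=O)NCc1ccc(F)cc1F)c(=O)n2O`) shares the core of compound 2 but carries 2-(dimethylcarbamoyl)ethenyl in place of 3-cyclohexylpropyl on an aromatic carbon so that the six-membered non-aromatic ring of carbon only leaves with the chain. Within the data shown here, no measured pair differs in just one place, so the size of this step in this assay remains a judgement. A clear rise beyond the usual scatter is expected, resting thinly on compound 2 at 27400 nM having the lower of the two readings. The expected change is a 4.0-fold higher number from compound 2 to compound 3 (0.60 log units; beyond the scatter) and it would point toward lower toxicity. The estimated value for compound 3 is 110000 nM with an expected range from 40000 nM to 250000 nM as a best guess.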

Compound 3, half-maximal cytotoxic concentration: > 250000 nM
Compound 3 ended at the assay's limit; the forecaster's own chance of this, stated with the estimate: 40%; middle value at least 2.2-fold (0.35 log units) from the limit.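

In this assay, within the data shown here, this is the first step at this position that can be read, and it is an at least 9.1-fold higher number from compound 2 to compound 3 (0.96 log units; beyond the scatter). It shows that the reading is not fixed by the shared core alone: with that core kept, putting 2-(dimethylcarbamoyl)ethenyl in place of 3-cyclohexylpropyl on this aromatic carbon moves the reading beyond the scatter, toward lower toxicity in this test. The full size of the step stays unknown, since compound 3 sits at a limit of the assay and the step is only a lower bound: the limit of > 250000 nM in this assay, at which 2 of the 3 values shown sit.

This one change removes the six-membered non-aromatic ring of carbon only and brings in the dimethylamide and the double bond all at once, so the compounds shown cannot tell which of these parts goes with the step. As far as these compounds go, it also stays open how this position would read in the same assay with an open-chain alkyl group without the ring, with a saturated 2-(dimethylcarbamoyl)ethyl chain, or with an amine or a carboxylic acid at the end of the chain.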